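Swapping the aryl group: from methoxy-methyl to fluoro-methyl

The compounds below may be only part of what the source reports. "The series", "measured", "known", "first", "only" and "open" are said of these compounds alone.

Of the compounds shown here, three sharing one core have been tested in a functional assay on KB cells (Homo sapiens) for antiproliferative activity, read by sulforhodamine B assay, with a stated time of 3 days; on this read-out higher numbers stand for an effect only at larger amounts of compound and lower numbers for an effect already at smaller amounts. Compound 1 `CCC1=C(O)c2c(oc(-c3cccc(OC)c3)cc2=O)C(CC)(CC)C1=O` gives 13.3 uM in this assay. Compound 2 `CCC1=C(O)c2c(oc(-c3ccc(C)c(F)c3)cc2=O)C(CC)(CC)C1=O` gives 28.1 uM. Compound 3 `CCC1=C(O)c2c(oc(-c3ccc(OC)cc3C)cc2=O)C(CC)(CC)C1=O` gives 20.9 uM. On these numbers compound 3 sits in the middle, and both neighbouring gaps are within the scatter: a 1.6-fold higher number from compound 1 to compound 3 (0.20 log units; within the scatter) and a 1.3-fold lower number from compound 2 to compound 3 (0.13 log units; within the scatter). Among the measured compounds shown here, the only step clearly beyond the scatter is a 2.1-fold higher number from compound 1 to compound 2 (0.32 log units; beyond the scatter), where a ring carrying a fluorine and a methyl group replaces one carrying a methoxy group.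

Compound 4 `CCC1=C(O)c2c(oc(-c3cc(C)ccc3F)cc2=O)C(CC)(CC)C1=O` differs from compound 3 in one place: 2-fluoro-5-methylphenyl in place of 4-methoxy-2-methylphenyl on an aromatic carbon. The methoxy group is lost, and a fluorine and a methyl group are present instead, as in compound 2. The step from compound 1 to compound 2 is the closest guide, since it also trades a methoxy for a fluoro-methyl pattern, and the step from compound 2 to compound 3 shows that the two arrangements of substituents there gave numbers within the scatter of each other. Compound 4 is therefore expected to land near compound 2, with a step from compound 3 of about a 1.2-fold higher number from compound 3 to compound 4 (0.09 log units; within the scatter), which may itself be within the scatter. The estimate for compound 4 in this assay is 26 uM, with a range from 12 uM to 55 uM.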

Compound 4, concentration for half-maximal effect: 47.3 uM
For compound 4 the middle estimate is 1.8-fold (0.26 log units) below the measured one; measured number inside the range.
By their numbers in this assay, from the lowest: compounds 1, 3, 2 and 4 (each within the scatter of the next, the first and the last beyond it).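

Compound 4 shows that moving the fluorine and the methyl around the ring does not clearly separate the two fluoro-methyl compounds: 2-fluoro-5-methylphenyl in place of 3-fluoro-4-methylphenyl gives a 1.7-fold higher number from compound 2 to compound 4 (0.23 log units; within the scatter) in this assay and so cannot be read as a real change. Against the two methoxy rings the new ring stands apart, with a 2.3-fold higher number from compound 3 to compound 4 (0.35 log units; beyond the scatter) and a 3.6-fold higher number from compound 1 to compound 4 (0.55 log units; beyond the scatter), so at this position on the shared core, both rings carrying a methoxy group give lower numbers than 2-fluoro-5-methylphenyl; compound 2 only partly follows this pattern, since its number lies beyond the scatter from compound 1 but within it from compound 3. Nothing available here explains why these numbers differ.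

Every group shown at this position is a phenyl ring carrying methoxy, methyl or fluorine, so it remains open how a ring bearing an amine or a carboxylic acid would behave. From the compounds shown here alone, it is also open whether a bare phenyl ring, or one with a single fluorine or a single methyl group, would give numbers nearer compound 1 or compound 4.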